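Chloro-to-hydrogen step on the fused core: expectation for compound 4

This account rests on a few compounds, and the source may have more. Where it says the series, first, only, none or still open, it means among the compounds named here.

Measured so far in a functional assay on UO-31 cells (Homo sapiens) for cytotoxicity, read by sulforhodamine B assay, with a stated time of 48 h; a higher number here means a weaker inhibitor of growth, a lower number a stronger inhibitor of growth:
compound 1 `ClCc1cccc(Cn2cnc3ncnc(Cl)c32)c1` gives 3090 nM
compound 2 `ClCc1ccc(Cn2cnc3nc(Cl)nc(Cl)c32)cc1` gives 2880 nM
compound 3 `ClCc1cccc(Cn2cnc3nc(Cl)nc(Cl)c32)c1` gives 35500 nM

Compound 2 has the lowest number of the three; compound 1 stands within the scatter of it, while compound 3 lies well beyond. Compounds 2 and 3 are built from the same atoms joined differently, and the difference between the two is not broken down here.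

One change has a measured precedent. From compound 3 to compound 1 the change is hydrogen in place of chloro on an aromatic carbon, and it gave an 11-fold lower number from compound 3 to compound 1 (1.06 log units; beyond the scatter) in this assay.

The unmeasured compound 4 `ClCc1ccc(Cn2cnc3ncnc(Cl)c32)cc1` is related to compound 2 by hydrogen in place of chloro on an aromatic carbon. The place of this change is the same as in the pair of compound 3 and compound 1, so it is the same change, seen for the second time in this set.

Starting from compound 2, which already gives 2880 nM, the expected step in this assay is a 4.1-fold lower number from compound 2 to compound 4 (0.61 log units; beyond the scatter). Among the measured compounds shown here, this expectation rests on the single precedent an 11-fold lower number from compound 3 to compound 1 (1.06 log units; beyond the scatter) and is taken as smaller because compound 3 gives 35500 nM, a much higher starting number than compound 2. The two starting cores are not broken down here. Compound 4 is accordingly estimated at 700 nM in this assay, with a plausible range from 150 nM to 3500 nM.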

Compound 4, concentration for total growth inhibition: 66100 nM
For compound 4 the middle estimate is 94-fold (1.98 log units) below the measured one; measured number above the stated range.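

In this assay, hydrogen in place of chloro on an aromatic carbon, between two ring nitrogen atoms, gives a 23-fold higher number from compound 2 to compound 4 (1.36 log units; beyond the scatter), and the same change runs the opposite way on the other core: the same change on two cores in this assay, an 11-fold lower number (1.06 log units; beyond the scatter) from compound 3 to compound 1 and a 23-fold higher number (1.36 log units; beyond the scatter) from compound 2 to compound 4, 260-fold (2.42 log units) apart, beyond the scatter of two such steps

The sign of this step therefore does not carry from one core to the other in this series, and the step from one pair gives no usable forecast for the other pair. What the two pairs do show is that the effect of removing this chloro depends on the rest of the molecule, at least for these four compounds. They do not show which structural feature sets the direction, since compound 2 and compound 3 are built from the same atoms joined differently, and two pairs are too few to support a rule for any further core.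

Still open, from the compounds shown here alone, is whether other groups on that aromatic carbon, such as an amine or a methoxy group, would also give opposite results on the two cores. Also open, going by these compounds, is whether the split between the cores persists when the chloromethyl group gives way to a longer chain or an alcohol, or when the compounds are read on other cell lines.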